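Replacing the substituted pyrazole group of compound 1

A few compounds are considered here, and "the series" means these few. Any claim that something is new, unique, unknown or untested is made for them only; others in the source may bear on it.

Measured so far in a physicochemical assay for lipophilicity, using the shake flask method, at pH 7.4; on this read-out higher numbers stand for higher lipophilicity and lower numbers for lower lipophilicity:
compound 1 `CCCC(Oc1ccc(-n2cc(C(F)(F)F)c(C)n2)cc1)c1ccc(C(=O)NCCC(=O)O)cc1`: 2.8
compound 2 `O=C(O)CCNC(=O)c1ccc(C(Oc2ccc(-n3cc(C(F)(F)F)cn3)cc2)C2CCCC2)cc1`: 3.3
compound 3 `CC(C)CC(Oc1ccc(-n2cc(C(F)(F)F)cn2)cc1)c1ccc(C(=O)NCCC(=O)O)cc1`: 3.2

Compound 1 holds the lowest number of the three in this assay, and its gaps to compound 2 and compound 3 both lie beyond the scatter. The unmeasured compound 4 `CCCC(Oc1ccc(-n2cc(Cl)cn2)cc1)c1ccc(C(=O)NCCC(=O)O)cc1` differs from compound 1 in one place: 4-chloro-1H-pyrazol-1-yl in place of 3-methyl-4-(trifluoromethyl)-1H-pyrazol-1-yl on an aromatic carbon. Going by the values given here, the only measured single-place step, a number 0.10 log units lower from compound 2 to compound 3 (within the scatter), has isobutyl in place of cyclopentyl on the saturated chain carbon. Among the compounds with values here, it lies within the scatter and does not touch the group changed here, so no measured step gives a size for this change. The expectation rests on the structural change alone, with the group that enters being the smaller one, and on compound 1 at 2.8. A modest move to a lower number, of uncertain size, is expected in this assay. The expected step is a number 0.40 log units lower from compound 1 to compound 4 (beyond the scatter). For compound 4 the estimated value is 2.4, with an expected range of 2 to 2.9.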

Compound 4, distribution coefficient: 2.6
For compound 4 the middle estimate is 0.20 log units below the measured one, and the stated range covers the measured number.
By their numbers in this assay, from the lowest: compounds 4 and 1 (each within the scatter of the next); then compounds 3 and 2 (each within the scatter of the next).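

In this assay, going by these compounds alone, a number 0.20 log units lower from compound 1 to compound 4 (within the scatter), so the one measured change at this position, on an aromatic carbon para to a large group, gives a step that stays inside the usual scatter. The group that enters, 4-chloro-1H-pyrazol-1-yl, holds fewer heavy atoms than 3-methyl-4-(trifluoromethyl)-1H-pyrazol-1-yl, with the same hydrogen-bond donor and acceptor counts, yet compound 1 and compound 4 cannot be told apart on this read-out. No supporting data bear on why the two stand so close.

With the chain of compound 1, only these two pyrazole groups are shown, so the separate shares of the methyl and the trifluoromethyl stay unread, and compound 2 and compound 3 differ from compound 1 in more than one place. As far as these compounds go, how a nitrile or an amine in place of the chlorine of compound 4 would read in this assay also remains open.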